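Trading a propyl for a hydroxy on the carbonyl carbon

The source may hold more compounds than are shown below. What is called first, only, known or untested is meant among the compounds shown, and "the series" means these compounds.

Of the compounds shown here, three sharing one core have been tested in a functional assay for inhibition of nuclear factor NF-kappa-B complex (Homo sapiens); a higher number here means a weaker inhibitor, a lower number a stronger inhibitor. Compound 1, `CCCC(=O)C1=Cc2ccc(OC)cc2OC1c1cc(OC)c(OC)c(OC)c1`, gives 11700 nM and stands at the lowest of the three numbers. Compound 2, `CCOC(=O)C1=Cc2ccc(OC)cc2OC1c1cc(OC)c(OC)c(OC)c1`, gives 25000 nM, and compound 3, `COc1ccc2c(c1)OC(c1cc(OC)c(OC)c(OC)c1)C(C=O)=C2`, gives 13500 nM. The two steps that change the group on the carbonyl carbon are small: a 2.1-fold higher number from compound 1 to compound 2 (0.33 log units; beyond the scatter), while a 1.2-fold higher number from compound 1 to compound 3 (0.06 log units; within the scatter). The new compound 4, `COc1ccc2c(c1)OC(c1cc(OC)c(OC)c(OC)c1)C(C(=O)O)=C2`, is compound 1 with one change: hydroxy in place of propyl on a carbonyl carbon. Both earlier swaps at this same carbonyl carbon weakened inhibition only modestly or not beyond the scatter, so a hydroxy entering in place of propyl is expected to give at most a similar weakening. The estimate for compound 4 is therefore 20000 nM in this assay, with a range from 8000 nM to 50000 nM. This would be an expected step of a 1.7-fold higher number from compound 1 to compound 4 (0.23 log units; within the scatter).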

Compound 4, half-maximal inhibitory concentration: > 50000 nM
Compound 4 ended at the assay's limit (the forecaster's own chance of this, stated with the estimate: 15%); middle value at least 2.5-fold (0.39 log units) from the limit.
By their numbers in this assay, from the lowest: compounds 1, 3 and 2 (each within the scatter of the next, the first and the last beyond it). At a limit, above all of these: compound 4.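

In this assay, compound 4 stands at a limit and not at a number: the limit of > 50000 nM in this assay, at which 1 of the 4 values shown sits. Even so, this carbonyl carbon proves less forgiving than the first three compounds suggested, since hydroxy here gives an at least 4.2-fold higher number from compound 1 to compound 4 (0.63 log units; beyond the scatter) and, measured against hydrogen, an at least 3.7-fold higher number from compound 3 to compound 4 (0.56 log units; beyond the scatter). Removing the ethyl from the ester oxygen gives an at least 2.0-fold higher number from compound 2 to compound 4 (0.30 log units; that floor lies within the scatter), a floor that does not by itself set these two compounds apart.

The true size of all three steps cannot be read past the limit. Going by these compounds, it also remains open how an amide or a methyl ketone on this carbonyl carbon would compare, and so whether the loss goes with the hydroxy itself or with other groups of similar size.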